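Swapping the Sulfonyl Substituent in a Weak Kinase-Type Series

The source may report more compounds than this note shows. Statements on the series, on what has been measured and on what is new or still open speak of the compounds shown alone.

Three compounds share a core and were tested in a functional assay on K562 cells (Homo sapiens) for inhibition, read by trypan blue exclusion, with a stated time of 72 h; on this read-out lower numbers stand for stronger inhibition and higher numbers for weaker inhibition. Compound 1 `Cn1c(=O)c(S(=O)(=O)Cc2ccc(F)cc2)cc2cnc(Nc3ccc4[nH]ccc4c3)nc21` gives 30000 nM, the highest number among the three and thus the weakest inhibition shown. Compound 2 `Cn1c(=O)c(C(=O)Nc2ccc(F)cc2)cc2cnc(Nc3ccc4[nH]ccc4c3)nc21` gives 5000 nM, and the step of a 6.0-fold lower number from compound 1 to compound 2 (0.78 log units; beyond the scatter) shows that exchanging the sulfonyl-linked group for an amide-linked one brought a clear gain. Compound 3 `Cn1c(=O)c(S(=O)(=O)c2ccccc2)cc2cnc(Nc3ccc4cc[nH]c4c3)nc21` gives 10000 nM; it carries a plain phenyl on the sulfonyl sulfur and differs from compound 1 also in how the indole is joined, so its two values can only be compared, not traced to one change.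

Compound 4 `Cn1c(=O)c(S(=O)(=O)c2ccc([N+](=O)[O-])cc2F)cc2cnc(Nc3ccc4[nH]ccc4c3)nc21` changes compound 1 at a single spot: 2-fluoro-4-nitrophenyl in place of 4-fluorobenzyl on a sulfonyl sulfur. Going by the values given here, no measured step covers exactly this change. Among the compounds with values here, the only guide is that compound 3, with an aromatic ring sitting directly on the sulfonyl sulfur, gives 10000 nM against 30000 nM for compound 1, which points toward a somewhat lower number when the sulfur carries an aryl group rather than a benzyl group. Compound 4 is therefore expected to give roughly 10000 nM, a step of a 3.0-fold lower number from compound 1 to compound 4 (0.48 log units; beyond the scatter) that is estimated to lie a little beyond the scatter, with an expected range from 3000 nM to 30000 nM.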

Compound 4, half-maximal inhibitory concentration: 200 nM
Compound 4: the middle estimate sits 50-fold (1.70 log units) above what was measured, and the stated range ends above it.
By their numbers in this assay, from the lowest: compound 4; then compounds 2 and 3 (each within the scatter of the next); then compound 1.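

Going by these compounds alone, at this position, the group on the sulfonyl sulfur matters far more than the earlier compounds could show: in this assay, placing 2-fluoro-4-nitrophenyl where 4-fluorobenzyl stood gives a 150-fold lower number from compound 1 to compound 4 (2.18 log units; beyond the scatter). That large step dwarfs the modest one seen when the whole sulfonyl-linked group gave way to an amide-linked group, a 6.0-fold lower number from compound 1 to compound 2 (0.78 log units; beyond the scatter). Compound 1 and compound 4 both keep the sulfonyl link, so the weak number of compound 1 cannot be blamed on that link alone, and nothing measured here explains why this exchange has so large an effect.

This single exchange changes several things at once, since a benzyl group gives way to a phenyl ring and a nitro group enters, so the compounds shown cannot say which of these changes carries the step. An amine or a carboxylic acid in place of the nitro group, or a hydrogen in place of the ring fluorine, would help to separate those contributions and show how much of the step depends on the nitro group itself.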